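The source may hold more compounds than are shown below. What is called first, only, known or untested is meant among the compounds shown, and "the series" means these compounds.

Measured in a functional assay on HepG2 cells (Homo sapiens) for antiproliferative activity, read by MTT assay, with a stated time of 48 h; on this read-out higher numbers stand for weaker inhibition and lower numbers for stronger inhibition:
compound 1 `CCOc1ccc(NC(=O)Nc2cccc(CNc3nccnc3Cl)c2)cc1`: 7050 nM
compound 2 `Cc1ccc(NC(=O)Nc2cccc(CNc3nccnc3Cl)c2)cc1C`: 10700 nM

Compound 1 holds the lowest of the two numbers; its nearest neighbour is compound 2, and the step of a 1.5-fold higher number from compound 1 to compound 2 (0.18 log units; within the scatter) is within the scatter. Compound 3 `O=C(Nc1cccc(CNc2nccnc2Cl)c1)NC1CCCCC1` is unmeasured and differs from compound 1 by cyclohexyl in place of 4-ethoxyphenyl on an amide-type nitrogen. Going by the values given here, only the step from compound 1 to compound 2 bears on this, and it is a change between two aromatic groups at the same amide-type nitrogen, so it says little about a non-aromatic ring entering there. No step beyond the scatter is expected, a 1.3-fold higher number from compound 1 to compound 3 (0.11 log units; within the scatter). Compound 3 is estimated at 9000 nM, with a range from 3500 nM to 25000 nM.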

Compound 3, half-maximal inhibitory concentration: > 40000 nM
Compound 3 was reported as a limit; the forecaster's own chance of this, stated with the estimate: 10%; middle value at least 4.4-fold (0.64 log units) away from the limit.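

Compound 3 stands as a limit, not as a number: the limit of > 40000 nM in this assay, at which 1 of the 3 values shown sits. Cyclohexyl on the amide-type nitrogen gives an at least 5.6-fold higher number from compound 1 to compound 3 (0.75 log units; beyond the scatter), and against the other aromatic group it gives an at least 3.7-fold higher number from compound 2 to compound 3 (0.57 log units; beyond the scatter). In this assay, this position therefore responds to an aromatic ring giving way to a non-aromatic one, which the swap between two aromatic groups did not show.

From the compounds shown here alone, how far compound 3 lies past its limit stays open. Also open, going by these compounds, is whether any non-aromatic group is tolerated here, or how an unsubstituted phenyl, a benzyl or a pyridyl group would compare.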